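This account rests on a few compounds, and the source may have more. Where it says the series, first, only, none or still open, it means among the compounds named here.

In a functional assay on MOLT-4 cells (Homo sapiens) for cytotoxicity, read by CCK-8 assay, with a stated time of 24 h (on this read-out lower numbers stand for stronger inhibition and higher numbers for weaker inhibition), compound 1 `C=CC(=O)N1C(=O)CC(c2ccc([N+](=O)[O-])cc2)Sc2ccccc21` gives 91500 nM, compound 2 `C=CC(=O)N1C(=O)CC(c2ccccc2Cl)Sc2ccccc21` gives 80300 nM and compound 3 `C=CC(=O)N1C(=O)CC(c2ccc(-c3ccccc3)cc2)Sc2ccccc21` gives 97500 nM. The number for compound 3 is the highest of the three, yet its gaps to compound 1 and to compound 2 are both within the scatter, so the three compounds cannot be told apart on these numbers. Compound 4 `C=CC(=O)N1C(=O)CC(c2ccc(Cl)cc2)Sc2ccccc21` differs from compound 3 by chloro in place of phenyl on an aromatic carbon. Among the compounds with values here, the only measured step bearing on this exchange is a 1.1-fold higher number from compound 1 to compound 3 (0.03 log units; within the scatter), which stayed within the scatter; no measured pair here exchanges phenyl for chloro directly. On that basis no step beyond the scatter is expected in this assay, and the expected change a 1.1-fold lower number from compound 3 to compound 4 (0.06 log units; within the scatter) is small. Compound 4 is therefore estimated at 85000 nM, with a range from 40000 nM to 180000 nM.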

Compound 4, half-maximal inhibitory concentration: 82400 nM
For compound 4 the middle estimate is 1.0-fold (0.01 log units) above the measured one, within the range that was stated.
By their numbers in this assay, from the lowest: compounds 2, 4, 1 and 3 (each within the scatter of the next).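

In this assay, chloro in place of phenyl gives a 1.2-fold lower number from compound 3 to compound 4 (0.07 log units; within the scatter) and chloro in place of nitro gives a 1.1-fold lower number from compound 1 to compound 4 (0.05 log units; within the scatter), so these three groups on this aromatic carbon cannot be told apart. The new compound also allows a check of where chlorine sits on the phenyl: 4-chlorophenyl in place of 2-chlorophenyl gives a 1.0-fold higher number from compound 2 to compound 4 (0.01 log units; within the scatter), again without a readable effect. No supporting data explain these results. Going by these compounds, whether an amine or a carboxylic acid on this aromatic carbon would give a step beyond the scatter remains open.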